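The source may report more compounds than this note shows. Statements on the series, on what has been measured and on what is new or still open speak of the compounds shown alone.

Three compounds share one core and differ only in the group carried on an amine nitrogen. Compound 1 `Cc1cn([C@@H]2O[C@H](CO[Si](C)(C)C(C)(C)C)[C@@]3(OS(=O)(=O)C=C3NC(=O)c3ccccc3)[C@H]2O[Si](C)(C)C(C)(C)C)c(=O)n(C)c1=O` gives 9700 nM in a functional assay on HEL cells (Homo sapiens); on this read-out higher numbers stand for lower toxicity in this test and lower numbers for higher toxicity in this test. Compound 2 `COC(=O)CCNC1=CS(=O)(=O)O[C@@]12[C@@H](CO[Si](C)(C)C(C)(C)C)O[C@@H](n1cc(C)c(=O)n(C)c1=O)[C@@H]2O[Si](C)(C)C(C)(C)C` gives 94000 nM in this assay. Compound 3 `Cc1cn([C@@H]2O[C@H](CO[Si](C)(C)C(C)(C)C)[C@@]3(OS(=O)(=O)C=C3NCC(=O)C(N)=O)[C@H]2O[Si](C)(C)C(C)(C)C)c(=O)n(C)c1=O` gives 14500 nM in this assay. Compound 3 thus stands second highest of the three: its value and that of compound 1 lie within the scatter of each other, while compound 2 sits beyond the scatter above it. Compound 4 `C=C(C)C(=O)NC(=O)NC1=CS(=O)(=O)O[C@@]12[C@@H](CO[Si](C)(C)C(C)(C)C)O[C@@H](n1cc(C)c(=O)n(C)c1=O)[C@@H]2O[Si](C)(C)C(C)(C)C` alters the same position: ((1-methylethenyl)carbonyl)carbamoyl in place of (carbamoylcarbonyl)methyl on an amine nitrogen. The measured steps at this position were a 9.7-fold higher number from compound 1 to compound 2 (0.99 log units; beyond the scatter), a 1.5-fold higher number from compound 1 to compound 3 (0.17 log units; within the scatter) and a 6.5-fold lower number from compound 2 to compound 3 (0.81 log units; beyond the scatter), so changes here have ranged from none to modest, in both directions. For compound 4 a step of about a 1.0-fold higher number from compound 3 to compound 4 (0.01 log units; within the scatter) is therefore expected, with no clear direction, giving an estimated 15000 nM, within 5000 nM to 60000 nM.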

Compound 4, half-maximal cytotoxic concentration: 1200 nM
Compound 4: the middle estimate sits 13-fold (1.10 log units) above what was measured; measured number outside the range, below it.
By their numbers in this assay, from the lowest: compound 4; then compounds 1 and 3 (each within the scatter of the next); then compound 2.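

Compound 4 shows that changes at this position can also lower the number sharply, not only raise it. In this assay there is a 12-fold lower number from compound 3 to compound 4 (1.08 log units; beyond the scatter) and an 8.1-fold lower number from compound 1 to compound 4 (0.91 log units; beyond the scatter) and also a 78-fold lower number from compound 2 to compound 4 (1.89 log units; beyond the scatter) on the same core, which makes compound 4 the most toxic of the four in this test. Nothing available here explains this drop.

From the compounds shown here alone, it remains open whether the lower number goes with the 1-methylethenyl end or with the carbamoyl link on the amine nitrogen. A plain carbamoyl group at this position would help to separate the two.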